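A few compounds are considered here, and "the series" means these few. Any claim that something is new, unique, unknown or untested is made for them only; others in the source may bear on it.

In a functional assay, read by spectrophotometry, in phosphate buffer, with a stated time of 10 min, at pH 6.6 (a higher number here means that more compound is needed for the effect, a lower number that less compound is needed), compound 3 (`COC(=O)C1=C(C)NC(=O)NC1c1ccc(O)cc1`) gives 67 ug/mL and stands lowest of the three measured compounds. Compound 2 (`COC(=O)C1=C(C)NC(=O)NC1c1ccc(OC)cc1`) gives 206 ug/mL as the nearest number, and compound 1 (`CCOC(=O)C1=C(C)NC(=O)NC1c1cccc([N+](=O)[O-])c1`) gives 339 ug/mL as the furthest. Compound 4 (`COC(=O)C1=C(C)NC(=O)NC1c1ccc([N+](=O)[O-])cc1`) has nitro in place of hydroxy on an aromatic carbon of compound 3 (nitro in place of hydroxy on an aromatic carbon), para to a large group.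

For the measured compounds named here, one measured step bears on this oxygen: a 3.1-fold lower number from compound 2 to compound 3 (0.49 log units; beyond the scatter) came with hydrogen in place of methyl, and it is modest in size. Going by the values given here, compound 1 is the only measured compound with nitro, and its 339 ug/mL is the highest number so far, though it differs from compound 4 in more than this group. Among the compounds with values here, no measured step shows nitro replacing hydroxy directly, so the size remains uncertain.

A move to a higher number in this assay is expected, similar to or somewhat larger than the measured step and probably beyond the scatter, with a 4.2-fold higher number from compound 3 to compound 4 (0.62 log units; beyond the scatter) as the estimated step. For compound 4 the estimated value is 280 ug/mL with an expected range of 120 ug/mL to 650 ug/mL for now.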

Compound 4, half-maximal effective concentration: 170 ug/mL
For compound 4 the middle estimate is 1.6-fold (0.22 log units) above the measured one; low and high end bracket the measured number.
By their numbers in this assay, from the lowest: compound 3; then compounds 4, 2 and 1 (each within the scatter of the next).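

In this assay, nitro in place of hydroxy on the aromatic carbon para to a large group comes with a 2.5-fold higher number from compound 3 to compound 4 (0.40 log units; beyond the scatter), so this position responds to this exchange, and the loss of hydroxy has a cost whether methyl caps the oxygen or nitro replaces the group. Nitro in place of methoxy comes with a 1.2-fold lower number from compound 2 to compound 4 (0.08 log units; within the scatter), which leaves these two groups indistinguishable here, so among the three groups tested at this position, only hydroxy stands apart from the others. Nothing available gives a reason for either step.

From the compounds shown here alone, whether an amine or a carboxylic acid on this carbon would fall with hydroxy or with methoxy and nitro stays open. Also open, going by these compounds, is whether a second hydroxy on the same ring would move the number further in the direction hydroxy already gives.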